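A few compounds are considered here, and "the series" means these few. Any claim that something is new, unique, unknown or untested is made for them only; others in the source may bear on it.

Of the compounds shown here, three built on closely related cores have been tested in a functional assay on MCF7 cells (Homo sapiens) for cytotoxicity, read by MTT assay, with a stated time of 24 h; a lower number here means a stronger inhibitor, a higher number a weaker inhibitor. Compound 1, `Cc1cc(-c2nc3cc(Cl)ccc3o2)ccc1NC(=O)CN1CCN(CCN(C)C)CC1`, carries a 2-(dimethylamino)ethyl chain on a ring amine nitrogen and a chlorine on its core; in this assay compound 1 gives 39300 nM. Compound 2, `CN(C)CCCN1CCN(CC(=O)Nc2ccc(-c3nc4cc(F)ccc4o3)cc2)CC1`, has a fluorine on its core and a 3-(dimethylamino)propyl chain; in this assay compound 2 gives 14800 nM. Compound 3, `CN(C)CCN1CCN(CC(=O)Nc2ccc(-c3nc4cc(F)ccc4o3)cc2)CC1`, shares the core of compound 2 but carries the shorter 2-(dimethylamino)ethyl chain; in this assay compound 3 gives 20800 nM.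

The pair of compound 3 and compound 2 isolates one change: (dimethylamino)methyl in place of dimethylamino on a saturated chain carbon, two bonds along the chain from an amine nitrogen in a ring. That change gave a 1.4-fold lower number from compound 3 to compound 2 (0.15 log units; within the scatter), so lengthening the chain by one carbon made no difference that can be trusted. The difference between the core of compound 1 and the core of compound 3 is not broken down here.

Compound 4, `Cc1cc(-c2nc3cc(Cl)ccc3o2)ccc1NC(=O)CN1CCN(CCCN(C)C)CC1`, is the chain-lengthened partner of compound 1, made by the same change: (dimethylamino)methyl in place of dimethylamino on a saturated chain carbon, two bonds along the chain from an amine nitrogen in a ring. Going by the values given here, since the only measured example of this change, from compound 3 to compound 2, stayed within the scatter, the step is expected to be small, about a 1.4-fold lower number from compound 1 to compound 4 (0.15 log units; within the scatter), resting on a 1.4-fold lower number from compound 3 to compound 2 (0.15 log units; within the scatter). Compound 4 is therefore estimated at 28000 nM in this assay, with a likely range from 12000 nM to 60000 nM.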

Compound 4, half-maximal inhibitory concentration: 63400 nM
Beside the measured number, compound 4's estimate is 2.3-fold (0.35 log units) below it; measured number above the stated range.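

In this assay, going from the 2-(dimethylamino)ethyl chain to the 3-(dimethylamino)propyl chain on the core of compound 1 gave a 1.6-fold higher number from compound 1 to compound 4 (0.21 log units; within the scatter), so on this core too the added carbon made no difference that can be trusted. Set beside the earlier step, the result gives no sign that the change behaves differently on the two cores: the same change on two cores in this assay, a 1.4-fold lower number (0.15 log units; within the scatter) from compound 3 to compound 2 and a 1.6-fold higher number (0.21 log units; within the scatter) from compound 1 to compound 4, 2.3-fold (0.36 log units) apart, within the scatter of two such steps. Going by these compounds alone, this shows that, in these two pairs, the change stayed too small to read on either core, but it does not show that the two cores respond identically, and with only two small steps and cores that differ in more than one place, it offers no general rule for other cores.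

From the compounds shown here alone, it remains open whether a longer chain, such as 4-(dimethylamino)butyl, or a diethylamino group at the end of the chain would shift the number beyond the scatter. Also open, going by these compounds, is what a hydroxyl group in place of dimethylamino would do, and whether the same chain change would stay this small on a core carrying bromine instead of chlorine or fluorine.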